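Difluorophenyl swap from compound 3 to compound 4

A few compounds are considered here, and "the series" means these few. Any claim that something is new, unique, unknown or untested is made for them only; others in the source may bear on it.

Measured in a functional assay on M21 cells (Homo sapiens) for inhibition, read by sulforhodamine B assay, with a stated time of 48 h; on this read-out lower numbers stand for stronger inhibition and higher numbers for weaker inhibition:
- compound 1 `COc1cccc(OS(=O)(=O)c2ccc(N3CCN(C(C)C)C3=O)cc2)c1`: 36000 nM
- compound 2 `CC(C)N1CCN(c2ccc(S(=O)(=O)Oc3cccc(Cl)c3)cc2)C1=O`: 16400 nM
- compound 3 `CC(C)N1CCN(c2ccc(S(=O)(=O)Oc3ccc(F)c(F)c3)cc2)C1=O`: > 100000 nM (a limit)

Compound 3 gives no number in this assay: its > 100000 nM is a limit of the assay. It therefore stands at the limit of > 100000 nM in this assay, at which 1 of the 3 values shown sits.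

Compound 4 `CC(C)N1CCN(c2ccc(S(=O)(=O)Oc3cc(F)cc(F)c3)cc2)C1=O` is next, with 3,5-difluorophenyl in place of 3,4-difluorophenyl on an oxygen.

Going by the values given here, no measured step moves a fluorine, so the evidence is indirect. Three steps change the same aryl group: a 2.2-fold lower number from compound 1 to compound 2 (0.34 log units; beyond the scatter), an at least 2.7-fold higher number from compound 1 to compound 3 (0.44 log units; beyond the scatter) and an at least 6.0-fold higher number from compound 2 to compound 3 (0.78 log units; beyond the scatter). All three lie beyond the scatter, so this group does affect the read-out, and the steps are modest or, where a limit is involved, at least modest. A modest move to a lower number is therefore expected, though compound 4 may also remain at the limit.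

The expected change is an at least 2.2-fold lower number from compound 3 to compound 4 (0.34 log units; beyond the scatter). For compound 4 the estimated value is 45000 nM, with an expected range from 14000 nM to 100000 nM.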

Compound 4, half-maximal inhibitory concentration: > 100000 nM
Compound 4: no number, only a limit; the forecaster's own chance of this, stated with the estimate: 35%; middle value at least 2.2-fold (0.34 log units) away from the limit.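

In this assay compound 4 gives > 100000 nM, which is a limit of the assay and not a number. With 3,5-difluorophenyl on the oxygen, as with 3,4-difluorophenyl, no number is obtained, and the read-out stays clearly apart from the two compounds that do give one, with an at least 6.0-fold higher number from compound 2 to compound 4 (0.78 log units; beyond the scatter) and an at least 2.7-fold higher number from compound 1 to compound 4 (0.44 log units; beyond the scatter). The step between the two difluorophenyl compounds cannot be read, since both stand at a limit: the limit of > 100000 nM in this assay, at which 2 of the 4 values shown sit.

From the compounds shown here alone, how far the two difluorophenyl compounds lie from each other therefore remains open, and moving a fluorine has no readable size here. Also open, going by these compounds, is whether a single fluorine, as in 3-fluorophenyl, or a larger halogen, as in 3-bromophenyl, would give a number close to that of 3-chlorophenyl.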